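A few compounds are considered here, and "the series" means these few. Any claim that something is new, unique, unknown or untested is made for them only; others in the source may bear on it.

Measured compounds:
compound 1 `C=C(Br)C(=O)Nc1ccc(/C=C/C(=O)c2ccccc2)cc1`: 3100 nM
compound 2 `C=C(Br)C(=O)Nc1ccc(/C=C/C(=O)c2cccc(OC)c2)cc1`: 850 nM
compound 3 `C=C(Br)C(=O)Nc1ccc(C(=O)/C=C/c2ccccc2)cc1`: 500 nM

All three were run in a functional assay on MOLT-4 cells (Homo sapiens) for antiproliferative activity, with a stated time of 48 h; on this read-out lower numbers stand for stronger inhibition and higher numbers for weaker inhibition. Compound 1 and compound 2 share one core, and compound 2 carries methoxy in place of hydrogen on an aromatic carbon, which gave a 3.6-fold lower number from compound 1 to compound 2 (0.56 log units; beyond the scatter). Compound 3 has the same atoms as compound 1 joined differently; the difference between the two cores is not broken down here. The numbers for compound 3 and compound 2 lie within the scatter of each other, so no order between them is claimed, while compound 1 stands beyond the scatter of compound 3.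

Compound 4 `C=C(Br)C(=O)Nc1ccc(C(=O)/C=C/c2ccc(OC)cc2)cc1` is not yet measured. It carries methoxy in place of hydrogen on an aromatic carbon on the core of compound 3. Among the measured compounds shown here, this is the same kind of change as the one from compound 1 to compound 2, not the same: in compound 2 the methoxy sits meta to a large group, in compound 4 it sits para to a large group, and the cores differ as noted.

For the measured compounds named here, for this assay the expected step is a 2.0-fold lower number from compound 3 to compound 4 (0.30 log units; within the scatter), set beside the measured step of a 3.6-fold lower number from compound 1 to compound 2 (0.56 log units; beyond the scatter), because a 3.6-fold lower number from compound 1 to compound 2 (0.56 log units; beyond the scatter) is the only guide to a methoxy on this kind of ring here, and the change of core and of place makes it a looser guide. Compound 4 is accordingly expected to give 250 nM in this assay, with 80 nM to 800 nM as the expected range.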

Compound 4, half-maximal inhibitory concentration: 610 nM
The estimate for compound 4 lay 2.4-fold (0.39 log units) below the measured number; measured number inside the range.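

In this assay, methoxy in place of hydrogen on an aromatic carbon of the core of compound 3 gives a 1.2-fold higher number from compound 3 to compound 4 (0.09 log units; within the scatter), so no order is claimed between these two compounds. The change therefore does not carry over with the same size from the core of compound 1 to the core of compound 3, as the two steps differ: the same change on two cores in this assay, a 3.6-fold lower number (0.56 log units; beyond the scatter) from compound 1 to compound 2 and a 1.2-fold higher number (0.09 log units; within the scatter) from compound 3 to compound 4, 4.4-fold (0.65 log units) apart, beyond the scatter of two such steps. This does not show that the core alone sets the size of the step, since the methoxy of compound 4, para to a large group, does not stand in the same place as the methoxy of compound 2, and this single pair of steps gives no general rule for the series.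

Still open, on these data alone, is whether the gap follows the core or the place of the methoxy, which only the same placement on both cores could separate. Also open, as far as these compounds go, is how an amine, a carboxylic acid or a longer chain such as ethoxy on the same aromatic carbon would read in this assay, on either core.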